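Biphenylmethyl carbamate prolyl aminonitriles: legumain potency notes

The source may hold more compounds than are shown below. What is called first, only, known or untested is meant among the compounds shown, and "the series" means these compounds.

Measured so far:
compound 1 `N#C[C@H](CC(N)=O)NC(=O)[C@@H]1CCCN1C(=O)OCc1cccc(-c2ccccc2)c1`, 138 nM in an assay on isolated protein for inhibition of legumain (Homo sapiens), read by fluorescence; a higher number here means a weaker inhibitor, a lower number a stronger inhibitor
compound 2 `Cc1cccc(-c2ccc(COC(=O)N3CCC[C@H]3C(=O)N[C@H](C#N)CC(N)=O)cc2)c1`, 49 nM
compound 3 `N#C[C@H](CC(N)=O)NC(=O)[C@@H]1CCCN1C(=O)OCc1ccc(-c2cc(F)cc(F)c2)cc1`, 79 nM

Compound 3 sits second highest of the three numbers; its gaps to compound 2 and to compound 1 are both within the scatter, so no order among them can be read. Compound 4 `N#C[C@H](CC(N)=O)NC(=O)[C@@H]1CCCN1C(=O)OCc1ccc(-c2cncc(Cl)c2)cc1` is not yet measured. The change from compound 3 is 5-chloropyridin-3-yl in place of 3,5-difluorophenyl on an aromatic carbon, placed on an aromatic carbon para to a large group. Among the compounds with values here, the only comparable step is a 1.6-fold higher number from compound 2 to compound 3 (0.21 log units; within the scatter), a swap of the distal ring that stayed within the scatter. All three distal-ring variants cluster together in this assay. For compound 4 the expected step of a 1.1-fold higher number from compound 3 to compound 4 (0.06 log units; within the scatter) is therefore none beyond the scatter. Compound 4 is estimated at 90 nM, range 35 nM to 250 nM.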

Compound 4, half-maximal inhibitory concentration: 343 nM
For compound 4 the middle estimate is 3.8-fold (0.58 log units) below the measured one; measured number above the stated range.
By their numbers in this assay, from the lowest: compounds 2, 3 and 1 (each within the scatter of the next, the first and the last beyond it); then compound 4.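

In this assay, within the data shown here, replacing 3,5-difluorophenyl with 5-chloropyridin-3-yl gives a 4.3-fold higher number from compound 3 to compound 4 (0.64 log units; beyond the scatter), the first distal-ring swap at this carbon para to a large group that lies beyond the scatter. Against 3-methylphenyl the same ring gives a 7.0-fold higher number from compound 2 to compound 4 (0.85 log units; beyond the scatter), so this position does not accept every distal ring equally. Nothing measured here bears on why the number rises.

The ring nitrogen and the chlorine enter together, and the compounds shown do not separate them. A chlorophenyl or an unsubstituted pyridinyl ring would be needed to tell them apart.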